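The source may hold more compounds than are shown below. What is called first, only, known or untested is meant among the compounds shown, and "the series" means these compounds.

Compound 1 `Cc1ccc(-c2nc(CNc3ccc(C(=O)NO)cc3)n(-c3ccccc3)n2)s1` and compound 2 `O=C(NO)c1ccc(NCc2nc(-c3ccc(C(F)(F)F)cc3)nn2-c2ccccc2)cc1` share one core and differ in a single group. In an assay on Sf9 cells for inhibition of protein deacetylase HDAC6 (Homo sapiens), read by fluorescence, with a stated time of 40 min, tested at 100 nM (on this read-out higher numbers stand for more inhibition at the one concentration tested (going by the name of the read-out) and lower numbers for less inhibition), compound 1 gives 79.7%, while compound 2 gives 41.6%. Among the compounds with values here, the one measured step between them is a number 38.1 percentage points lower from compound 1 to compound 2 (beyond the scatter). On these two numbers compound 2 stands lowest, with compound 1 the nearest and well beyond the scatter above it.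

Compound 3 `O=C(NO)c1ccc(NCc2nc(-c3ccncc3)nn2-c2ccccc2)cc1` differs from compound 2 in one place: pyridin-4-yl in place of 4-(trifluoromethyl)phenyl on an aromatic carbon. Within the data shown here, the only measured step bears on this change because a number 38.1 percentage points lower from compound 1 to compound 2 (beyond the scatter) was made at the same aromatic carbon of the five-membered aromatic ring with 3 nitrogen, and it was large. It swapped a different pair of groups, however, and no measured compound carries pyridin-4-yl, so the direction for this change is not shown by the data. From the compounds shown here alone, both directions remain open, and the expected step is a number 6.4 percentage points higher from compound 2 to compound 3 (within the scatter), of uncertain sign and likely not beyond the scatter. Compound 3 is estimated at 48%, with a range from 22% to 74%.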

Compound 3, a percentage reported as inhibition, at one concentration (the size of the read-out at that concentration, not a potency): 30.8%
Compound 3: middle estimate off by 17.2 percentage points, on the high side; low and high end bracket the measured number.
By their numbers in this assay, from the lowest: compound 3; then compound 2; then compound 1.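

In this assay, the change to pyridin-4-yl settles a direction that was open before: a number 10.8 percentage points lower from compound 2 to compound 3 (beyond the scatter), a modest step but beyond the scatter. The wider step a number 48.9 percentage points lower from compound 1 to compound 3 (beyond the scatter) shows that, among these three compounds, the two groups with a six-membered aromatic ring both read below 5-methylthiophen-2-yl, so this aromatic carbon is sensitive to the group it carries. The change from compound 2 to compound 3 removes the trifluoromethyl group, reduces the size of the group and adds a ring nitrogen with a hydrogen-bond acceptor all at once, and no measurement here explains why the number falls.

From the compounds shown here alone, it remains open whether the higher number of compound 1 belongs to its five-membered ring or to its methyl group, and a thiophen-2-yl without the methyl, a plain phenyl or a 4-methylphenyl at this carbon would help separate these features. It is also unknown how an amine or a carboxylic acid on the aromatic ring at this position would read, and these numbers come from one concentration, so they do not give potencies.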